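The source may report more compounds than this note shows. Statements on the series, on what has been measured and on what is new or still open speak of the compounds shown alone.

In a functional assay, read by spectrophotometry, tested at 100 uM (a lower number here means a stronger inhibitor, a higher number a weaker inhibitor), compound 1 `O=C(/C=C/c1cccs1)c1cccc(NC(=O)c2cc(-c3ccncc3)n[nH]2)c1` gives 70000 nM and compound 2 `O=C(/C=C/c1ccco1)c1cccc(NC(=O)c2cc(-c3ccncc3)n[nH]2)c1` gives 72300 nM, and these two values lie within the scatter of each other. Compound 3 `O=C(/C=C/c1ccccc1Cl)c1cccc(NC(=O)c2cc(-c3ccncc3)n[nH]2)c1` has not yet been measured. It differs from compound 2 in one place: 2-chlorophenyl in place of furan-2-yl on a double-bonded chain carbon bound to a double-bonded chain carbon. Here, 2-chlorophenyl stands in place of furan-2-yl on a double-bonded chain carbon bound to a double-bonded chain carbon. Among the compounds with values here, one measured step bears on this change, at the same place: a 1.0-fold higher number from compound 1 to compound 2 (0.01 log units; within the scatter). Within the data shown here, that step only exchanged thiophen-2-yl for furan-2-yl, so it is a limited guide to a six-membered aromatic ring of carbon only, and no measured compound carries 2-chlorophenyl. No step beyond the scatter is therefore expected in this assay, and no direction is favoured. The estimated step is a 1.1-fold lower number from compound 2 to compound 3 (0.05 log units; within the scatter). Compound 3 is expected at about 65000 nM, with an estimated range of 30000 nM to 100000 nM.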

Compound 3, half-maximal inhibitory concentration: 79800 nM
Beside the measured number, compound 3's estimate is 1.2-fold (0.09 log units) below it; measured number inside the range.
By their numbers in this assay, from the lowest: compounds 1, 2 and 3 (each within the scatter of the next).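

In this assay, replacing the five-membered furan-2-yl ring with 2-chlorophenyl, a six-membered aromatic ring of carbon only with more heavy atoms and no hydrogen-bond acceptor, gives a 1.1-fold higher number from compound 2 to compound 3 (0.04 log units; within the scatter) at this place on the chain. Set against the thiophen-2-yl compound, the same group gives a 1.1-fold higher number from compound 1 to compound 3 (0.06 log units; within the scatter) and so extends the earlier comparison, which covered only one five-membered ring against another, to a larger ring carrying chlorine. In these three compounds, this assay therefore does not separate the two five-membered rings from 2-chlorophenyl, and nothing available explains that result.

A plain phenyl ring would show whether the chlorine makes any difference to this reading. On these data alone, it also remains open whether a group of a different kind here, such as an amine, a carboxylic acid or a saturated cyclohexyl ring, would separate from these three.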